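The compounds below may be only part of what the source reports. "The series", "measured", "known", "first", "only" and "open" are said of these compounds alone.

Of the compounds shown here, three that share one core have been tested, and they differ only in the aromatic group on the chain. In a functional assay on K562 cells (Homo sapiens) for antiproliferative activity, read by MTT assay, with a stated time of 24 h (on this read-out lower numbers stand for stronger inhibition and higher numbers for weaker inhibition), compound 3 `COc1ccc(C(=O)/C=C/c2ccc(Cl)cc2)c2c1C=CC(C)(C)O2` gives > 10000 nM, which is a limit of the assay and not a number. Compound 1 `COc1ccc(C(=O)/C=C/c2cccc(F)c2)c2c1C=CC(C)(C)O2` gives > 10000 nM, which is also a limit. Compound 3 therefore stands with compound 1 at the limit of > 10000 nM in this assay, at which 2 of the 3 values shown sit. Only compound 2 `COc1ccc(C(=O)/C=C/c2cccc([N+](=O)[O-])c2)c2c1C=CC(C)(C)O2` has a true number, 5870 nM.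

Compound 4 `COc1ccccc1/C=C/C(=O)c1ccc(OC)c2c1OC(C)(C)C=C2` keeps the core and brings 2-methoxyphenyl in place of 4-chlorophenyl on a double-bonded chain carbon bound to a double-bonded chain carbon. Three measured steps swap this same aromatic group. They are an at least 1.7-fold lower number from compound 1 to compound 2 (0.23 log units; that floor lies within the scatter), an at least 1.7-fold higher number from compound 2 to compound 3 (0.23 log units; that floor lies within the scatter) and a step that the two limits leave unreadable from compound 1 to compound 3. None of them shows a change beyond the scatter, so no step beyond the scatter is expected in this assay. The estimate amounts to a number no higher from compound 3 to compound 4 (the limit leaves the size open), an expected step of unreadable size. For compound 4 the expected value is 10000 nM, with an estimated range from 4000 nM to 25000 nM.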

Compound 4, half-maximal inhibitory concentration: > 10000 nM
Compound 4 ended at the assay's limit; the forecaster's own chance of this, stated with the estimate: 65%; the middle value lies on the limit itself.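

In this assay, a methoxy-bearing aromatic group in this place, with a hydrogen-bond acceptor that 4-chlorophenyl lacks, still gives only a limit and no true number, so the limit now holds for a third aromatic group: the limit of > 10000 nM in this assay, at which 3 of the 4 values shown sit. Among the compounds shown here, the one readable new step is an at least 1.7-fold higher number from compound 2 to compound 4 (0.23 log units; that floor lies within the scatter), so compound 2, the only compound with a true number, is still not set apart beyond the scatter, here from compound 4. The steps from compound 1 and from compound 3 to compound 4 cannot be read, as both ends of each are limits.

Where the true values of compound 1, compound 3 and compound 4 lie, and whether they differ from one another, stays open. Also open, on these data alone, is what an amine or a carboxylic acid on this aromatic ring would give in this assay.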